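The source may hold more compounds than are shown below. What is called first, only, known or untested is meant among the compounds shown, and "the series" means these compounds.

Compound 1 `CN(C)c1ccc(/C=C(/SCc2ccc(Cl)cc2)C(=O)c2ccc(C(=O)O)cc2)cc1`: 1000 nM
Compound 2 `CN(C)c1ccc(/C=C(/SCc2ccc(Br)cc2)C(=O)c2ccc(C(=O)O)cc2)cc1`: 50000 nM
Compound 3 `CN(C)c1ccc(/C=C(/SCc2ccc(F)cc2)C(=O)c2ccc(C(=O)O)cc2)cc1`: 10000 nM
Compound 4 `CN(C)c1ccc(/C=C(\C(=O)c2ccc(C(=O)O)cc2)S(=O)(=O)Cc2ccc(Cl)cc2)cc1`: not yet measured

These numbers come from a functional assay on DU-145 cells (Homo sapiens) for inhibition, read by trypan blue exclusion, with a stated time of 96 h; on this read-out higher numbers stand for weaker inhibition of growth and lower numbers for stronger inhibition of growth. Compound 3 gives 10000 nM and holds the middle place among the three measured compounds. Compound 4 differs from it by (4-chlorobenzyl)sulfonyl in place of (4-fluorobenzyl)sulfanyl on a double-bonded chain carbon bound to a carbonyl carbon and a double-bonded chain carbon. In words, this is (4-chlorobenzyl)sulfonyl in place of (4-fluorobenzyl)sulfanyl on a double-bonded chain carbon bound to a carbonyl carbon and a double-bonded chain carbon. Only the halogen part of this change has a measured counterpart. Read in reverse, a 10-fold higher number from compound 1 to compound 3 (1.00 log units; beyond the scatter) suggests that chloro in place of fluoro could lower the number. The step of a 50-fold higher number from compound 1 to compound 2 (1.70 log units; beyond the scatter) shows that a single halogen swap here can also be large. Among the compounds with values here, no measured pair shows what sulfonyl in place of sulfanyl does, so part of the fluoro-to-chloro gain is held back and the range is kept wide. A modest fall in this assay is therefore expected, and the expected step is a 3.3-fold lower number from compound 3 to compound 4 (0.52 log units; beyond the scatter). Compound 4 is estimated at 3000 nM, with an expected range from 300 nM to 30000 nM.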

Compound 4, concentration for 50% growth inhibition: > 100000 nM
Compound 4: only a limit was reported; the forecaster's own chance of this, stated with the estimate: 10%; middle value at least 33-fold (1.52 log units) from the limit.
By their numbers in this assay, from the lowest: compound 1; then compound 3; then compound 2. At a limit, above all of these: compound 4.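

In this assay compound 4 gives only a limit of the assay, > 100000 nM. The clearest reading is an at least 100-fold higher number from compound 1 to compound 4 (2.00 log units; beyond the scatter), where the chloro stays and only sulfonyl replaces sulfanyl on the double-bonded chain carbon, so the earlier compounds, which varied the halogen alone, could not have shown this large loss of growth inhibition. The steps of an at least 10-fold higher number from compound 3 to compound 4 (1.00 log units; beyond the scatter) and an at least 2.0-fold higher number from compound 2 to compound 4 (0.30 log units; that floor lies within the scatter) also change the halogen, and the floor of the second lies within the scatter, so it adds little on its own.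

The compounds shown leave open how a sulfinyl group at this place would compare with sulfanyl and sulfonyl. They also leave open whether a methyl ester in place of the carboxylic acid would change the outcome of this sulfonyl swap.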